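Side-chain extension on a purine glycinamide series

The compounds below may be only part of what the source reports. "The series", "measured", "known", "first", "only" and "open" are said of these compounds alone.

Measured so far:
compound 1 `O=C(CN(c1ncnc2c1ncn2C1CCCCO1)C1CC1)NCC(=O)OCc1ccccc1` — 7.26%
compound 2 `O=C(CN(c1nc(Cl)nc2[nH]cnc12)C1CC1)N[C@@H](CCC(=O)OCc1ccccc1)C(=O)OCc1ccccc1` — 44.5%
compound 3 `C[C@@H](O)[C@H](NC(=O)CN(c1nc(Cl)nc2[nH]cnc12)C1CC1)C(=O)O` — 24%

In a functional assay on the whole organism (Tail, strain ICR) with Mus musculus as the target, in the tail flick test, with a stated time of 150 min, at a dose of 25 umol/kg by the oral route (on this read-out higher numbers stand for a stronger effect at the one dose given and lower numbers for a weaker effect), compound 1 gives 7.26%, the lowest of the three numbers. Its nearest neighbour is compound 3, which gives 24%, a gap beyond the scatter, and the furthest is compound 2, which gives 44.5%, also beyond the scatter. Compounds 2 and 3 differ from compound 1 in more than one place, so none of these gaps can be laid to a single change.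

Compound 4 `CC(C)(C)OC(=O)NCCCC[C@H](NC(=O)CN(c1ncnc2c1ncn2C1CCCCO1)C1CC1)C(=O)OCc1ccccc1` has not been measured in this assay. It differs from compound 1 in one place: 4-((tert-butoxycarbonyl)amino)butyl in place of hydrogen on a saturated chain carbon bound to an amide-type nitrogen and a carbonyl carbon. Compounds 2 and 3, which carry a substituent at that same chain carbon, both stand higher than compound 1, though their cores also differ. On that basis a rise is expected, as a number 14.7 percentage points higher from compound 1 to compound 4 (beyond the scatter), with wide uncertainty. Compound 4 is therefore estimated at 22%, between 5% and 45%.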

Compound 4, a percentage reported as activity, at one dose (the size of the read-out at that dose, not a potency): 17.2%
The estimate for compound 4 lay 4.8 percentage points above the measured number; measured number inside the range.
By their numbers in this assay, from the lowest: compounds 1, 4 and 3 (each within the scatter of the next, the first and the last beyond it); then compound 2.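

With the core of compound 1 held fixed, 4-((tert-butoxycarbonyl)amino)butyl in place of hydrogen on a saturated chain carbon bound to an amide-type nitrogen and a carbonyl carbon gives, in this assay, a number 9.9 percentage points higher from compound 1 to compound 4 (within the scatter) and so cannot be told apart from no change at this one dose. Among the compounds shown here, this is the only step that isolates the position, as compounds 2 and 3 also differ from compound 1 elsewhere and cannot be read for it. Nothing given here bears on why the read-out stays within the scatter.

The compounds shown leave open whether a free primary amine at the end of the butyl chain, a carboxylic acid there, or a shorter chain would separate from hydrogen. They also leave open whether 4-((tert-butoxycarbonyl)amino)butyl would give the same result on the core of compound 2.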